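This account rests on a few compounds, and the source may have more. Where it says the series, first, only, none or still open, it means among the compounds named here.

Measured compounds:
- compound 1, `Nc1ccccc1NC(=O)c1ccc(CSC(=S)N2CCN(c3ccc(F)cc3)CC2)cc1`, gives 76.3% in a functional assay on A-375 cells (Homo sapiens) for antiproliferative activity, read by CCK-8 assay, with a stated time of 72 h, tested at 8 uM; a lower number here means a weaker effect, a higher number a stronger effect of the compound at the concentration tested
- compound 2, `CN1CCN(C(=S)SCc2ccc(C(=O)Nc3ccccc3N)cc2)CC1`, gives 91.6% in this assay

For the measured compounds named here, compound 2 stands highest of the two numbers so far; its nearest neighbour is compound 1, and the step of a number 15.3 percentage points higher from compound 1 to compound 2 (beyond the scatter) puts compound 1 well below it, beyond the usual scatter. That step swapped a 4-fluorophenyl group for a methyl group on an amine nitrogen in a ring, and the methyl compound came out stronger.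

Compound 3, `Nc1ccccc1NC(=O)c1ccc(CSC(=S)N2CCN(c3ccccc3F)CC2)cc1`, has not yet been tested. Its change from compound 2 is 2-fluorophenyl in place of methyl on an amine nitrogen in a ring. Going by the values given here, this is close to the reverse of the one measured step: a methyl group leaves the ring nitrogen and a fluorophenyl group, now a 2-fluorophenyl, enters in its place. Among the compounds with values here, only the step from compound 1 to compound 2 bears on it, and that step was of modest size. A drop of roughly the same size is therefore expected, with a number 13.6 percentage points lower from compound 2 to compound 3 (beyond the scatter) as the estimated step. Compound 3 is expected to give about 78%, within a range from 64% to 90%.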

Compound 3, a percentage reported as inhibition, at one concentration (the size of the read-out at that concentration, not a potency): 79.5%
Beside the measured number, compound 3's estimate is 1.5 percentage points below it; measured number inside the range.
By their numbers in this assay, from the lowest: compounds 1 and 3 (each within the scatter of the next); then compound 2.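

In this assay, a second fluorophenyl group on the ring nitrogen now comes with a lower number than methyl: a number 12.1 percentage points lower from compound 2 to compound 3 (beyond the scatter) is a drop beyond the scatter, much like the one that separates compound 1 from compound 2, so among these three compounds the methyl compound stands clear of both fluorophenyl compounds. The new compound also allows a comparison that was not possible before, between two placements of the fluorine on the phenyl ring: with a number 3.2 percentage points higher from compound 1 to compound 3 (within the scatter) lying within the scatter, 2-fluorophenyl and 4-fluorophenyl cannot be told apart here. No measurement on these compounds explains the gap between methyl and the fluorophenyl groups.

From the compounds shown here alone, with only these groups in hand, it remains open whether the lower numbers go with the phenyl ring, with the fluorine, or with neither, and a hydrogen, an ethyl group or an unsubstituted phenyl group on this ring nitrogen would bear on that question. A 3-fluorophenyl group also lies outside the compounds shown, and as each number comes from one concentration, how the three compare in potency stays open too.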